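This account rests on a few compounds, and the source may have more. Where it says the series, first, only, none or still open, it means among the compounds named here.

Compound 3, `CCCCCCCCCCCCCCCSC[C@H](NC(C)=O)C(=O)CCl`, is the weaker of the two compounds with a definite number in a functional assay on MOLT-3 cells (Homo sapiens); on this read-out lower numbers stand for stronger inhibition and higher numbers for weaker inhibition: compound 3 gives 8600 nM, whereas compound 1, `CCCCCCCCCCSC[C@H](NC(C)=O)C(=O)CCl`, gives 3400 nM, so that the step of a 2.5-fold higher number from compound 1 to compound 3 (0.40 log units; beyond the scatter) is a modest loss. Compound 2, `CCCCCCCCCCCCCSC[C@H](NC(C)=O)C(=O)CCl`, reaches only the limit of this assay, as compound 2 gives > 100000 nM. That limit is the point (the limit of > 100000 nM in this assay, at which 1 of the 3 values shown sits).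

Compound 4, `CCCCCCCCCCCCCCCCCCSC[C@H](NC(C)=O)C(=O)CCl`, differs from compound 3 by propyl in place of hydrogen on a saturated chain carbon, ten or more bonds along the chain from a sulfur. All three measured steps involve the same kind of change, lengthening of the saturated chain far from the sulfur, and they do not point in one direction. The step of an at least 29-fold higher number from compound 1 to compound 2 (1.46 log units; beyond the scatter) is a large loss, the step of an at least 11-fold lower number from compound 2 to compound 3 (1.06 log units; beyond the scatter) is a large gain, and the step of a 2.5-fold higher number from compound 1 to compound 3 (0.40 log units; beyond the scatter) is a modest loss. Adding propyl to compound 1 gave the poorest result, while adding pentyl cost comparatively little, so the effect of extra chain length here is erratic rather than steady.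

Given this, compound 4 is expected to be somewhat weaker than compound 3, with the step of a 2.3-fold higher number from compound 3 to compound 4 (0.37 log units; beyond the scatter) as the estimate, and a real chance that compound 4 also only reaches the limit of this assay. The expected value for compound 4 is 20000 nM, within a range from 4000 nM to 100000 nM.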

Compound 4, half-maximal inhibitory concentration: > 100000 nM
Compound 4 gave a limit, no number; the forecaster's own chance of this, stated with the estimate: 35%; middle value at least 5.0-fold (0.69 log units) from the limit.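

In this assay compound 4 gives > 100000 nM, which is a limit of the assay and not a number. The definite activity of compound 3 does not carry over to the longer chain, as the large loss of an at least 11-fold higher number from compound 3 to compound 4 (1.06 log units; beyond the scatter) shows, and the longest chain also ends far from compound 1, with an at least 29-fold higher number from compound 1 to compound 4 (1.46 log units; beyond the scatter), while the step between compound 2 and compound 4 cannot be read, as both values are limits. Adding propyl at this place on the chain has now brought a large loss twice, although compound 3 still goes against any simple rule that a longer chain means weaker inhibition, since it has a longer chain than compound 2 yet gives a definite number: the same change on two cores in this assay, an at least 29-fold higher number (1.46 log units; beyond the scatter) from compound 1 to compound 2 and an at least 11-fold higher number (1.06 log units; beyond the scatter) from compound 3 to compound 4; the limit leaves it open whether they differ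

From the compounds shown here alone, with so many values at the limit, the true size of these losses stays unknown, and so does any real pattern of chain length: the limit of > 100000 nM in this assay, at which 2 of the 4 values shown sit. Also open is how a chain shorter than that of compound 1 would behave, or a chain carrying an amine or a carboxylic acid.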